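From Ethyl to Methyl: Compound 2 to Compound 4

The source may report more compounds than this note shows. Statements on the series, on what has been measured and on what is new or still open speak of the compounds shown alone.

Of the compounds shown here, three sharing one core have been measured in an assay on CHO cells for displacement of a labelled ligand from adenosine receptor A1 (Homo sapiens), read by scintillation counting, with a stated time of 3 h; a higher number here means a weaker inhibitor, a lower number a stronger inhibitor. Compound 1 `Cn1c(-c2ccccc2)nc2c(NC3CCCC3)ncnc21` gives 2.8 nM, compound 2 `CCn1c(-c2ccccc2)nc2c(NC3CCC3)ncnc21` gives 6 nM, and compound 3 `CCn1c(-c2ccccc2)nc2c(N)ncnc21` gives 31 nM. Compound 2 therefore stands second of the three: its nearest neighbour is compound 1, whose number is lower beyond the scatter, and its furthest is compound 3. Among the measured compounds shown here, the only single-point step among them, a 5.2-fold higher number from compound 2 to compound 3 (0.71 log units; beyond the scatter), concerns hydrogen in place of cyclobutyl on a nitrogen on an aromatic ring, a different place from the one considered here.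

Compound 4 `Cn1c(-c2ccccc2)nc2c(NC3CCC3)ncnc21` differs from compound 2 as follows: hydrogen in place of methyl on a saturated chain carbon bound to an aromatic nitrogen. For the measured compounds named here, no measured step touches this place. Compound 1 and compound 2 do differ there, but they also differ in cyclopentyl versus cyclobutyl, so their gap cannot be attributed to the ethyl-to-methyl change alone. With nothing bearing directly on it, the step is expected to remain within the scatter: a 1.2-fold lower number from compound 2 to compound 4 (0.08 log units; within the scatter). Compound 4 is accordingly estimated at 5 nM, with a range from 2 nM to 12 nM.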

Compound 4, inhibition constant: 3.2 nM
Compound 4: middle estimate off by 1.6-fold (0.19 log units), on the high side, within the range that was stated.
By their numbers in this assay, from the lowest: compounds 1, 4 and 2 (each within the scatter of the next, the first and the last beyond it); then compound 3.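

In this assay, the change from ethyl to methyl at this position, on a saturated chain carbon bound to an aromatic nitrogen, can now be read alone with the cyclobutyl group held constant, and it stays within the scatter (a 1.9-fold lower number from compound 2 to compound 4 (0.27 log units; within the scatter)). Compound 4 also isolates the other place with the methyl group held constant: cyclobutyl in place of cyclopentyl on a nitrogen on an aromatic ring likewise stays within the scatter (a 1.1-fold higher number from compound 1 to compound 4 (0.06 log units; within the scatter)). No measurement shown accounts for either step.

The compounds shown leave open whether a longer chain such as propyl, or a chain ending in an amine, would also stay within the scatter at this position. They also leave open how a cyclohexyl group would read on the nitrogen on an aromatic ring.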